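The source may report more compounds than this note shows. Statements on the series, on what has been measured and on what is new or still open speak of the compounds shown alone.

In a functional assay on PC-3 cells (Homo sapiens) for inhibition, read by MTT assay, with a stated time of 48 h, tested at 10 uM (on this read-out lower numbers stand for less inhibition of growth and higher numbers for more inhibition of growth at the one concentration tested), compound 1 `Cc1cc(=O)c2c(O)cc(OCc3ccc(Br)cc3)c([C@H]3CCN(C)C[C@H]3O)c2o1` gives 17% and compound 2 `Cc1cc(=O)c2c(O)c(CN3CCC(N4CCCCC4)CC3)c(O)c([C@H]3CCN(C)C[C@H]3O)c2o1` gives 17% while compound 3 `Cc1cc(=O)c2c(O)c(CN3CCCC3CO)c(O)c([C@H]3CCN(C)C[C@H]3O)c2o1` gives 15% at the one concentration tested. Compound 2 thus stands level with compound 1, and compound 3 lies within the scatter of both. Compound 4 `Cc1cc(=O)c2c(O)c(CN3CCC(c4ccccc4)CC3)c(O)c([C@H]3CCN(C)C[C@H]3O)c2o1`, not yet measured, differs from compound 2 by phenyl in place of piperidin-1-yl on a saturated ring carbon. For the measured compounds named here, no measured pair differing in one place is available as a guide, so no step beyond the scatter is expected in this assay for this change. The estimated change a number 3 percentage points higher from compound 2 to compound 4 (within the scatter) is expected to stay within the scatter. For compound 4 the estimated value is 20% with an expected range from 8% to 36% in this measurement.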

Compound 4, percent growth inhibition at one concentration: 22%
Compound 4: the middle estimate sits 2 percentage points below what was measured; the measured number falls inside the stated range.
By their numbers in this assay, from the lowest: compounds 3, 1, 2 and 4 (each within the scatter of the next).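

In this assay, for the compounds shown here, the exchange of piperidin-1-yl for phenyl on a saturated ring carbon gives a number 5 percentage points higher from compound 2 to compound 4 (within the scatter) and is the first step that can be read at this position. A non-aromatic ring with a hetero atom can thus give way to an aromatic ring of carbon only here without a change beyond the scatter. Nothing at hand accounts for this result. On these data alone, whether a carboxylic acid, a primary amine or a longer alkyl chain on this ring carbon would move the number beyond the scatter remains open.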